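Cytotoxicity limits and a methoxy swap on compound 2

The source may hold more compounds than are shown below. What is called first, only, known or untested is meant among the compounds shown, and "the series" means these compounds.

- compound 1 `Cc1cc(NC(=O)Nc2ccccc2N)c2ccccc2n1`: > 25000 nM
- compound 2 `Cc1cc(NC(=O)Nc2ccc(F)c(F)c2)c2ccccc2n1`: > 25000 nM
- compound 3 `Cc1cc(NC(=O)Nc2ccc(N(C)C)cc2)c2ccccc2n1`: > 25000 nM

In an ADME assay on BJ cells (Homo sapiens) for cytotoxicity, with a stated time of 72 h (on this read-out higher numbers stand for an effect only at larger amounts of compound and lower numbers for an effect already at smaller amounts), compound 2 gives > 25000 nM, which is a limit and not a number. Across the set, the picture is the limit of > 25000 nM in this assay, at which 3 of the 3 values shown sit. Compound 4 `COc1ccc(NC(=O)Nc2cc(C)nc3ccccc23)cc1F` carries methoxy in place of fluoro on an aromatic carbon, ortho to a fluoro group and para to a large group. Within the data shown here, no measured pair shows a change of this kind, so the only guide is the limit of > 25000 nM in this assay, at which 3 of the 3 values shown sit. The expected step of a number no higher from compound 2 to compound 4 (the limit leaves the size open) is none beyond the scatter in this assay, in either direction. Compound 4 is estimated at 25000 nM, with an expected range of 12000 nM to 50000 nM.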

Compound 4, half-maximal effective concentration: 26000 nM
Compound 4: middle estimate off by 1.0-fold (0.02 log units), on the low side, and the stated range covers the measured number.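

Among these compounds, the result for compound 2 is a limit and not a number, so no step from compound 2 to compound 4 can be read. The compounds shown give no readable size of change in this assay for methoxy in place of fluoro on an aromatic carbon.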